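Replacing 4-Chlorophenyl with 2-Methoxyphenyl on the Amide

A few compounds are considered here, and "the series" means these few. Any claim that something is new, unique, unknown or untested is made for them only; others in the source may bear on it.

Compound 1, `Cc1cccc(NC(=O)CSc2nnc(-c3ccoc3C)n2Cc2ccco2)c1C`, gives only a limit in a functional assay on CHO cells for antagonist activity at Orexin receptor type 2 (Homo sapiens), read by FLIPR and calcium flux; on this read-out higher numbers stand for weaker inhibition and lower numbers for stronger inhibition: > 15800 nM.
Compound 2, `Cc1cccc(NC(=O)CSc2nnc(-c3ccoc3C)n2Cc2ccco2)c1`: 50.1 nM.
Compound 3, `Cc1occc1-c1nnc(SCC(=O)Nc2ccc(Cl)cc2)n1Cc1ccco1`: 100 nM.

Compound 3 has the higher of the two real numbers, yet the difference is only a 2.0-fold higher number from compound 2 to compound 3 (0.30 log units; within the scatter), so the two cannot be told apart. Compound 1 sits at the limit (the limit of > 15800 nM in this assay, at which 1 of the 3 values shown sits). From there, an at least 310-fold lower number from compound 1 to compound 2 (2.49 log units; beyond the scatter) and an at least 150-fold lower number from compound 1 to compound 3 (2.19 log units; beyond the scatter) show how much a change on the phenyl attached to the amide nitrogen can matter.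

Compound 4, `COc1ccccc1NC(=O)CSc1nnc(-c2ccoc2C)n1Cc1ccco1`, differs from compound 3 by 2-methoxyphenyl in place of 4-chlorophenyl on an amide-type nitrogen. Among the measured compounds shown here, no measured step covers a methoxy group, but compound 1 carries the 2,3-dimethylphenyl group and reaches only the limit, while compound 2 with 3-methylphenyl and compound 3 with 4-chlorophenyl are both potent. The 2-methoxyphenyl group of compound 4 resembles compound 1 more than compound 2, so a clearly weaker result is expected, though with wide uncertainty. For compound 4 the expected step is a 30-fold higher number from compound 3 to compound 4 (1.48 log units; beyond the scatter), giving an estimate of 3000 nM, likely between 300 nM and 30000 nM.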

Compound 4, inhibition constant: 501 nM
Beside the measured number, compound 4's estimate is 6.0-fold (0.78 log units) above it; the range from low to high includes it.
By their numbers in this assay, from the lowest: compounds 2 and 3 (each within the scatter of the next); then compound 4. At a limit, above all of these: compound 1.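

In this assay, among the compounds shown here, 2-methoxyphenyl gives the first real number on this amide nitrogen that stands clear of the others, with a 5.0-fold higher number from compound 3 to compound 4 (0.70 log units; beyond the scatter) and a 10-fold higher number from compound 2 to compound 4 (1.00 log units; beyond the scatter). Compounds 2 and 3 cannot be told apart, but compound 4 shows that this position does not treat every substituted phenyl alike, although both of these steps are modest. With an at least 31-fold lower number from compound 1 to compound 4 (1.49 log units; beyond the scatter), the 2-methoxyphenyl group also avoids the full loss seen with 2,3-dimethylphenyl, and compound 1 remains a limit rather than a number: the limit of > 15800 nM in this assay, at which 1 of the 4 values shown sits.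

The compounds shown leave open whether the kind of group or its place on the ring decides the result, a question that 4-methoxyphenyl or 2-chlorophenyl on the same nitrogen could address. Also open, going by these compounds, is how a cyclohexyl group, which has no aromatic ring, would fare there.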